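The source may hold more compounds than are shown below. What is called first, only, known or untested is meant among the compounds shown, and "the series" means these compounds.

Compound 1 `CCS(=O)(=O)Nc1ccc(NC(=O)c2ccc(Cl)c([N+](=O)[O-])c2)cc1OC`: 5660 nM. Compound 2 `COc1cc(NC(=O)c2ccc(Cl)c([N+](=O)[O-])c2)ccc1NS(=O)(=O)C(F)(F)F`: > 250000 nM, a limit of the assay and not a number. Compound 3 `CCS(=O)(=O)Nc1ccc(NC(=O)c2cccc(C(F)(F)F)c2)cc1F`: 119000 nM.

In an ADME assay on RAW264.7 cells (Mus musculus) for cytotoxicity, read by MTT assay, with a stated time of 48 h (on this read-out lower numbers stand for stronger inhibition and higher numbers for weaker inhibition), compound 1 gives 5660 nM. Compound 2 reaches only the limit of > 250000 nM. The change trifluoromethyl in place of ethyl on a sulfonyl sulfur gives an at least 44-fold higher number from compound 1 to compound 2 (1.64 log units; beyond the scatter), a step whose size is bounded by the limit of > 250000 nM in this assay, at which 1 of the 3 values shown sits. Compound 3 gives 119000 nM in this assay; the difference between its core and that of compound 1 is not broken down here. Compound 4 `O=C(Nc1ccc(NS(=O)(=O)C(F)(F)F)c(F)c1)c1cccc(C(F)(F)F)c1` carries the same change, (trifluoromethyl in place of ethyl on a sulfonyl sulfur), on the same place. Since the step from compound 1 to compound 2 was an at least 44-fold higher number from compound 1 to compound 2 (1.64 log units; beyond the scatter), compound 4 is expected to move by a 2.5-fold higher number from compound 3 to compound 4 (0.40 log units; beyond the scatter) in this assay. Compound 4 is estimated at 300000 nM, between 120000 nM and 1500000 nM, most likely reported as a limit.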

Compound 4, half-maximal inhibitory concentration: 34400 nM
The estimate for compound 4 lay 8.7-fold (0.94 log units) above the measured number, outside the stated range (below it).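

In this assay trifluoromethyl in place of ethyl on a sulfonyl sulfur gives a 3.5-fold lower number from compound 3 to compound 4 (0.54 log units; beyond the scatter), so the change does not carry over from one core to the other, not even in direction: the same change on two cores in this assay, an at least 44-fold higher number (1.64 log units; beyond the scatter) from compound 1 to compound 2 and a 3.5-fold lower number (0.54 log units; beyond the scatter) from compound 3 to compound 4, at least 150-fold (2.18 log units) apart, beyond the scatter of two such steps

For compound 2, > 250000 nM is a limit of the assay and not a number. The two pairs show that the result of this change depends on the core, but they do not show which of the differences between the two cores goes with the reversal.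

On these data alone, it remains open how a methyl group or a longer chain such as propyl on the sulfonyl sulfur would behave on either core. As far as these compounds go, it is also open which way the change would go on a third core.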